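This account rests on a few compounds, and the source may have more. Where it says the series, first, only, none or still open, it means among the compounds named here.

Measured compounds:
Compound 1 `CC(C)(C)OC(=O)NCCCCNC(=O)CN1CN(c2ccccc2)C2(CCN(C(=O)c3ccc(C(C)(C)C)cc3)CC2)C1=O` — in an assay on HEK293 cells for displacement of a labelled ligand from NPC1-like intracellular cholesterol transporter 1 (Homo sapiens) (on this read-out higher numbers stand for weaker inhibition and lower numbers for stronger inhibition), compound 1 gives "not determined" (no result reported).
Compound 2 `CC(C)(C)OC(=O)NC1CCN(C(=O)CN2CN(c3ccccc3)C3(CCN(C(=O)c4ccc(C(C)(C)C)cc4)CC3)C2=O)CC1` — in this assay compound 2 gives 8300 nM.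
Compound 3 `CC(C)(C)OC(=O)NC1CCN(C(=O)CN2CN(c3ccccc3)C3(CCN(C(=O)c4ccc(C5CCCCC5)cc4)CC3)C2=O)CC1` — in this assay compound 3 gives 4800 nM.

Compound 2 stands at the highest of the two numbers shown, its nearest neighbour being compound 3 a 1.7-fold lower number from compound 2 to compound 3 (0.24 log units; within the scatter). The unmeasured compound 4 `CC(C)(C)OC(=O)NCC1CCN(C(=O)CN2CN(c3ccccc3)C3(CCN(C(=O)c4ccc(C(C)(C)C)cc4)CC3)C2=O)CC1` differs from compound 2 in one place: ((tert-butoxycarbonyl)amino)methyl in place of (tert-butoxycarbonyl)amino on a saturated ring carbon. Going by the values given here, the only measured step, from tert-butyl to cyclohexyl on the aromatic ring, sits at a different position and therefore says nothing direct about a change on the saturated ring carbon. No basis exists for expecting a move beyond the scatter, so compound 4 is estimated at 8000 nM, with a range of 3000 nM to 20000 nM. This estimate means the step of a 1.0-fold lower number from compound 2 to compound 4 (0.02 log units; within the scatter) is expected to be small.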

Compound 4, half-maximal inhibitory concentration: 4200 nM
For compound 4 the middle estimate is 1.9-fold (0.28 log units) above the measured one; measured number inside the range.
By their numbers in this assay, from the lowest: compounds 4, 3 and 2 (each within the scatter of the next).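

On the saturated ring carbon, three ring bonds from the ring nitrogen, ((tert-butoxycarbonyl)amino)methyl in place of (tert-butoxycarbonyl)amino gives a 2.0-fold lower number from compound 2 to compound 4 (0.30 log units; within the scatter) in this assay, so the two groups cannot be told apart here. Going by these compounds alone, this is the first step read at this position, and it stays at the edge of the scatter. Nothing available here bears on the reason for this result. Going by these compounds, it remains open whether a free amine, a carboxylic acid or a longer chain on this ring carbon would move the number beyond the scatter.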